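The source may hold more compounds than are shown below. What is called first, only, known or untested is meant among the compounds shown, and "the series" means these compounds.

Compound 1 `CN(C)c1ccc2cc(-c3ccccc3Cl)c(N)nc2c1`: 2400 nM
Compound 2 `CN(C)c1ccc2cc(-c3cccc(Cl)c3)c(N)nc2c1`: 13000 nM

Going by the values given here, in a toxicity assay on J774.A1 cells (Mus musculus) for cytotoxicity, read by SYBR Green assay, with a stated time of 1 h (a lower number here means that less compound is needed, a higher number that more compound is needed for the effect), compound 2 has the higher of the two numbers so far, so more of it is needed for the effect than of compound 1. The next compound, compound 3 `CN(C)c1ccc2cc(-c3cccc(Cl)c3Cl)c(N)nc2c1`, has a chloro in place of a hydrogen on an aromatic carbon of compound 2: chloro in place of hydrogen on an aromatic carbon. The new chloro sits ortho to the existing chloro group and ortho to a large group.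

Among the compounds with values here, only one measured step bears on this change: a 5.4-fold higher number from compound 1 to compound 2 (0.73 log units; beyond the scatter). That step swaps 2-chlorophenyl for 3-chlorophenyl, and compound 3 carries the chloro groups of both compound 1 and compound 2. Moving a chloro is not the same as adding one, and no measured pair shows an added chloro, so this expectation rests on thin evidence. The number for compound 3 is still expected to fall from that of compound 2 towards that of compound 1, 2400 nM.

The expected change is a 3.7-fold lower number from compound 2 to compound 3 (0.57 log units; beyond the scatter). For compound 3, the estimate is 3500 nM, with an expected range of 1200 nM to 10000 nM.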

Compound 3, half-maximal effective concentration: 4900 nM
Compound 3: middle estimate off by 1.4-fold (0.15 log units), on the low side; measured number inside the range.
By their numbers in this assay, from the lowest: compound 1; then compound 3; then compound 2.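

Going by these compounds alone, compound 3 gives the first measured pairs in which a chloro is added rather than moved, and in this assay the same kind of change runs in opposite directions. Adding a chloro ortho to the existing chloro group gives a 2.7-fold lower number from compound 2 to compound 3 (0.42 log units; beyond the scatter), whereas adding the other chloro, on the ring that already carries the 2-chlorophenyl chloro, gives a 2.0-fold higher number from compound 1 to compound 3 (0.31 log units; beyond the scatter), so in these two pairs the effect of an added chloro depends on which chloro is already there, and the number for the compound with both lies between those of the compounds with one. Nothing measured here explains this difference in direction.

Still open, as far as these compounds go, is whether a different group on the same aromatic carbon, such as a methoxy or an amine, would lower the number as the chloro does on compound 2, or whether this is particular to chloro. Also open, from the compounds shown here alone, is where a plain phenyl with no chloro at all would stand, which would show how each single chloro compares with hydrogen on this ring.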